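This account rests on a few compounds, and the source may have more. Where it says the series, first, only, none or still open, it means among the compounds named here.

Compound 1 `c1ccc(CNCC2CCN(CCCc3c[nH]c4ccc(-n5cnnc5)cc34)CC2)cc1`, compound 2 `CN(Cc1cccs1)C1CCN(CCCc2c[nH]c3ccc(-n4cnnc4)cc23)CC1` and compound 3 `OCCC(NC1CCN(CCCc2c[nH]c3ccc(-n4cnnc4)cc23)CC1)c1ccccc1` share one core and differ only in the group carried on the saturated ring. In an assay on CHO cells for agonist activity at 5-hydroxytryptamine receptor 1D (Homo sapiens), read by GTPgammaS binding (a higher number here means that more compound is needed for the effect, a lower number that less compound is needed), compound 1 gives 5.6 nM, compound 2 gives 3.5 nM and compound 3 gives 5.1 nM. Compound 3 stands second highest of the three numbers, and both neighbours lie within the scatter of it: a 1.1-fold lower number from compound 1 to compound 3 (0.04 log units; within the scatter), and a 1.5-fold higher number from compound 2 to compound 3 (0.16 log units; within the scatter). Compound 4 `C[C@@H](NC1CCN(CCCc2c[nH]c3ccc(-n4cnnc4)cc23)CC1)c1ccccc1` is the next variation at this position: 1-phenylethyl in place of 3-hydroxy-1-phenylpropyl on an amine nitrogen. Within the data shown here, the three measured steps, a 1.6-fold lower number from compound 1 to compound 2 (0.20 log units; within the scatter) among them, all exchange the group on that saturated ring carbon, and none of them moves the number beyond the scatter; they are the only guide this set offers for the change to compound 4. The expected step is a 1.0-fold lower number from compound 3 to compound 4 (0.01 log units; within the scatter), not beyond the scatter in either direction. Compound 4 is thus estimated at 5 nM in this assay, with a range from 2 nM to 12.5 nM.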

Compound 4, half-maximal effective concentration: 13 nM
The estimate for compound 4 lay 2.6-fold (0.41 log units) below the measured number; the measured number lies above the stated range.
By their numbers in this assay, from the lowest: compounds 2, 3 and 1 (each within the scatter of the next); then compound 4.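

In this assay, among these compounds, this is the first exchange at this position that carries the number beyond the scatter (in a 2.5-fold higher number from compound 3 to compound 4 (0.41 log units; beyond the scatter)), and the same holds against the other two compounds (a 2.3-fold higher number from compound 1 to compound 4 (0.37 log units; beyond the scatter); a 3.7-fold higher number from compound 2 to compound 4 (0.57 log units; beyond the scatter)). Among the compounds shown here, the position is therefore less indifferent than the earlier compounds suggested: compounds 1, 2 and 3 stay within the scatter of one another despite their different groups, while the 1-phenylethyl group of compound 4 stands apart from all three, if only modestly. No measurement at hand accounts for this shift.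

Going from compound 3 to compound 4 removes the hydroxyl and shortens the chain at once, and the compounds shown do not separate the two changes. A 1-phenylpropyl group on the same amine nitrogen would keep the chain without the hydroxyl, and the mirror-image form of 1-phenylethyl would test the defined stereocentre.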